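This account rests on a few compounds, and the source may have more. Where it says the series, first, only, none or still open, it means among the compounds named here.

Measured compounds:
Compound 1 `O=C(NCc1ccc(S(=O)(=O)c2ccccc2)cc1)N1CCc2ccncc2C1` — 310 nM
Compound 2 `CC(C)n1cc(S(=O)(=O)c2ccc(CNC(=O)N3Cc4ccncc4C3)cc2)cn1` — 20 nM

In an assay on isolated protein for inhibition of Nicotinamide phosphoribosyltransferase (Homo sapiens), read by mass spectrometry, with stated times of 15 min and 30 min (on this read-out higher numbers stand for weaker inhibition and lower numbers for stronger inhibition), compound 2 has the lowest of the two numbers, and compound 1 sits far above it, a gap beyond the usual scatter. Compound 3 `O=C(NCc1ccc(S(=O)(=O)N2CCOCC2)cc1)N1Cc2ccncc2C1` has not yet been measured in this assay. It differs from compound 2 in one place: morpholin-4-yl in place of 1-isopropyl-1H-pyrazol-4-yl on a sulfonyl sulfur. Going by the values given here, no measured pair shows this change, so its effect is uncertain. Compound 3 is expected to lose some potency, a step from a 5.0-fold higher number from compound 2 to compound 3 (0.70 log units; beyond the scatter), landing between the two measured numbers. The estimate for compound 3 in this assay is 100 nM, within a range of 30 nM to 400 nM.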

Compound 3, half-maximal inhibitory concentration: 71 nM
Compound 3: the middle estimate sits 1.4-fold (0.15 log units) above what was measured; the measured number falls inside the stated range.
By their numbers in this assay, from the lowest: compound 2; then compound 3; then compound 1.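

In this assay, swapping the aromatic 1-isopropyl-1H-pyrazol-4-yl on the sulfonyl sulfur for the non-aromatic morpholin-4-yl gives a 3.6-fold higher number from compound 2 to compound 3 (0.55 log units; beyond the scatter) and so costs only modest potency. This position therefore accepts a six-membered non-aromatic ring, although the loss is real rather than scatter. No available evidence explains this step. This single pair changes ring type, ring size and the hetero atoms all at once, so their separate contributions stay unresolved. As far as these compounds go, whether piperidine, which lacks the morpholine oxygen, or a small open-chain amine such as dimethylamine would behave alike also remains open.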